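The compounds below may be only part of what the source reports. "The series", "measured", "known", "first", "only" and "open" are said of these compounds alone.

Working notes on the series, read in an ADME assay on liver (Mus musculus) for metabolic stability, read by LC-MS, using microsomes and NADPH; on this read-out lower numbers stand for a less stable compound and higher numbers for a more stable compound. Compound 1 (`Cc1cc(CN(CC2CC2)C(CC(=O)O)c2ccc(Cl)cc2)ccc1OCCN1C(=O)CCC1=O`) gives 83% as the highest of the three numbers, and compound 2 (`CCCN(Cc1ccc(OCCn2c(=O)ccn(C)c2=O)c(C)c1)C(CC(=O)O)c1ccc(Cl)cc1`) gives 23% as the lowest. Compound 3 (`CCCN(Cc1ccc(OCCn2c(=O)ccn(C)c2=O)c(OC)c1)C(CC(=O)O)c1ccc(Cl)cc1`) stands second highest at 50% in this series.

The next structure is compound 4 (`COc1cc(CN(C2CCC2)C(CC(=O)O)c2ccc(Cl)cc2)ccc1OCCn1c(=O)ccn(C)c1=O`), which has cyclobutyl in place of propyl on an amine nitrogen relative to compound 3.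

Among the measured compounds shown here, only one measured step is available, and it does not concern this change. Methoxy in place of methyl on an aromatic carbon gives a number 27 percentage points higher from compound 2 to compound 3 (beyond the scatter) as a modest step beyond the scatter. It serves only as a gauge of how far one local change can move the number in this series. Compound 1 at 83% differs from compound 3 in more than one place, so its number cannot be assigned to the amine substituent alone. For the measured compounds named here, no measured pair isolates that substituent, which leaves the direction weakly supported and the range wide.

A small upward move is expected, with the estimated step being a number 8 percentage points higher from compound 3 to compound 4 (within the scatter) in this assay for now. For compound 4 the estimate is 58% with an expected range from 35% to 80% in repeat measurements.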

Compound 4, percent of the compound remaining: 51%
The estimate for compound 4 lay 7 percentage points above the measured number; low and high end bracket the measured number.
By their numbers in this assay, from the lowest: compound 2; then compounds 3 and 4 (each within the scatter of the next); then compound 1.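

In this assay, among the compounds shown here, the first measured step at this position is a number 1 percentage points higher from compound 3 to compound 4 (within the scatter), so the amine nitrogen carries either propyl or cyclobutyl with no difference that can be read. On the methoxy-bearing core shared by compound 3 and compound 4, the open chain and the four-membered ring of carbon only therefore cannot be told apart in this read-out, although the ring adds one carbon. The other measured single-place step, a number 27 percentage points higher from compound 2 to compound 3 (beyond the scatter), lies beyond the scatter, whereas this one does not, which places the clear movement so far at the aromatic methoxy or methyl site rather than at this nitrogen. No measurement at hand offers an explanation for this result.

From the compounds shown here alone, whether isopropyl, cyclopentyl or a longer chain on the amine nitrogen would stand apart from propyl and cyclobutyl remains open. Also open, going by these compounds, is whether cyclobutyl gives the same reading on the methyl-bearing core of compound 2, and the number of compound 1 still cannot be assigned to any single place.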